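Phenyl in Place of Methyl on a Small Ring

The source may report more compounds than this note shows. Statements on the series, on what has been measured and on what is new or still open speak of the compounds shown alone.

In a functional assay on MCF7 cells (Homo sapiens) for inhibition, read by MTT assay, with a stated time of 48 h (on this read-out higher numbers stand for weaker inhibition and lower numbers for stronger inhibition), compound 1 `CCn1c(C)cs/c1=N\NC(=O)COc1ccc2c(-c3ccccc3)cc(=O)oc2c1` gives 78 ug/mL and has just one measured neighbour for comparison. That neighbour, compound 2 `CC(=O)c1s/c(=N\NC(=O)COc2ccc3c(-c4ccccc4)cc(=O)oc3c2)n(C)c1C` with a different group on the amide-type nitrogen, gives 42 ug/mL and lies within the usual scatter of compound 1. Still unmeasured is compound 3 `CCn1c(-c2ccccc2)cs/c1=N\NC(=O)COc1ccc2c(-c3ccccc3)cc(=O)oc2c1` and it differs from compound 1 in one place. The change (phenyl in place of methyl on an aromatic carbon) is phenyl in place of methyl on an aromatic carbon. Going by the values given here, the only measured step is a 1.9-fold lower number from compound 1 to compound 2 (0.27 log units; within the scatter) and it concerns a different change, which leaves little direct guidance on phenyl. With that single step as the basis, no step beyond the scatter is expected in this assay in either direction. The step expected is a 1.3-fold lower number from compound 1 to compound 3 (0.11 log units; within the scatter) on this estimate. For compound 3 the estimated value is 60 ug/mL with an expected range from 25 ug/mL to 140 ug/mL in this read-out.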

Compound 3, half-maximal inhibitory concentration: 10.6 ug/mL
Estimate against measurement, compound 3: 5.7-fold (0.75 log units) above, outside the stated range (below it).
By their numbers in this assay, from the lowest: compound 3; then compounds 2 and 1 (each within the scatter of the next).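

In this assay, phenyl in place of methyl on this aromatic carbon, next to the ring nitrogen, gives a 7.4-fold lower number from compound 1 to compound 3 (0.87 log units; beyond the scatter) and so moves the number beyond the scatter. Going by these compounds alone, the only earlier step, a 1.9-fold lower number from compound 1 to compound 2 (0.27 log units; within the scatter), concerned a different change and stayed within the scatter, so this is the first sign that a change in this part of the molecule can bring clearly stronger inhibition. No measurement shown here accounts for the size of this step.

From the compounds shown here alone, whether the gain belongs to the aromatic ring itself or simply to a larger carbon group at this position remains open. A cyclohexyl group or a longer chain such as butyl on the same carbon would help separate the two, and an amine on the phenyl ring would test how far the ring can be changed.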